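The source may report more compounds than this note shows. Statements on the series, on what has been measured and on what is new or still open speak of the compounds shown alone.

Compound 1 `COC(=O)C[C@H](NC(=O)OC(C)(C)C)C(=O)N(Cc1ccccc1)C1(C(=O)NCc2ccccc2)CCN(Cc2ccccc2)CC1` is known only as a limit in an ADME assay on MDCK cells (Canis lupus familiaris) for cytotoxicity, read by microscopy, with a stated time of 72 h; on this read-out higher numbers stand for lower toxicity in this test and lower numbers for higher toxicity in this test: in this assay compound 1 gives > 100000 nM, which is a limit of the assay and not a number (the limit of > 100000 nM in this assay, at which 1 of the 3 values shown sits). Two related compounds give numbers. In this assay compound 2 `COC(=O)C[C@H](NC(=O)OC(C)(C)C)C(=O)N(Cc1ccc(F)cc1)C1(C(=O)NCc2ccccc2)CCN(C2CCCCC2)CC1` gives 73000 nM, and compound 3 `COC(=O)C[C@H](NC(=O)OC(C)(C)C)C(=O)N(Cc1ccc(F)cc1)C1(C(=O)NCc2ccccc2)CCN(c2ccccc2)CC1` gives 20000 nM. Among the measured compounds shown here, the step of a 3.7-fold lower number from compound 2 to compound 3 (0.56 log units; beyond the scatter) is the only measured step here, and it changes a different position from the one at issue. Compound 4 `COC(=O)C[C@H](NC(=O)OC(C)(C)C)C(=O)NC1(C(=O)NCc2ccccc2)CCN(Cc2ccccc2)CC1` differs from compound 1 by hydrogen in place of benzyl on an amide-type nitrogen. For the measured compounds named here, no measured step covers this change, so no step beyond the scatter is expected in this assay. Compound 4 is expected to give 100000 nM, within a range from 40000 nM to 250000 nM. The expected step is a number no higher from compound 1 to compound 4 (the limit leaves the size open).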

Compound 4, minimum cytotoxic concentration: 100000 nM
Beside the measured number, compound 4's estimate shows no gap at the digits printed; the measured number falls inside the stated range.
By their numbers in this assay, from the lowest: compound 3; then compounds 2 and 4 (each within the scatter of the next).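

In this assay compound 1 gives > 100000 nM, a limit of the assay and not a number. With hydrogen on this amide-type nitrogen, compound 4 gives 100000 nM, so this position can lose the benzyl and still give a number this high. The change is a number no higher from compound 1 to compound 4 (the limit leaves the size open), and its true size cannot be read: the limit of > 100000 nM in this assay, at which 1 of the 4 values shown sits.

Going by these compounds, what stays open is how a methyl, a longer chain or a chain ending in a carboxylic acid on this nitrogen would behave in this assay.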